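The compounds below may be only part of what the source reports. "The series", "measured", "known", "first", "only" and "open" are said of these compounds alone.

Measured compounds in an ADME assay on HEK293 cells (Homo sapiens) for cytotoxicity, read by MTT assay, with a stated time of 48 h; on this read-out higher numbers stand for weaker inhibition and lower numbers for stronger inhibition:

compound 1, `Cc1ccc(S(=O)(=O)/N=C(/CCNC2=CC(=O)c3ccccc3C2=O)Nc2cccc(C(F)(F)F)c2)cc1`: 91500 nM
compound 2, `COc1ccc(N/C(CCNC2=CC(=O)c3ccccc3C2=O)=N\S(=O)(=O)c2ccc(C)cc2)c(OC)c1`: 83000 nM
compound 3, `COc1cc(N/C(CCNC2=CC(=O)c3ccccc3C2=O)=N\S(=O)(=O)c2ccc(C)cc2)cc(OC)c1OC`: 75800 nM

All three share one core and differ only in the aryl group on the amine nitrogen. Compound 3 gives the lowest of the three numbers in this assay, but its separation from compound 2 and compound 1 is within the scatter, so no order among the three can be stated. The three steps between them, a 1.1-fold lower number from compound 1 to compound 2 (0.04 log units; within the scatter), a 1.2-fold lower number from compound 1 to compound 3 (0.08 log units; within the scatter) and a 1.1-fold lower number from compound 2 to compound 3 (0.04 log units; within the scatter), are each within the scatter: exchanging one aryl group for another has so far left the read-out unmoved.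

Compound 4, `Cc1ccc(S(=O)(=O)/N=C(/CCNC2=CC(=O)c3ccccc3C2=O)Nc2cc(F)c(F)c(F)c2)cc1`, is not yet measured. It differs from compound 3 by 3,4,5-trifluorophenyl in place of 3,4,5-trimethoxyphenyl on an amine nitrogen. Every measured step bears on this change in the same way, since each is an exchange of the aryl group on the amine nitrogen, and none moved this assay beyond the scatter. No step beyond the scatter is therefore expected for compound 4 in this assay, with the step from compound 3 estimated as a 1.1-fold higher number from compound 3 to compound 4 (0.03 log units; within the scatter).

Compound 4 is expected to give about 82000 nM in this assay, within an estimated range of 40000 nM to 170000 nM.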

Compound 4, half-maximal inhibitory concentration: 82600 nM
Compound 4: middle estimate off by 1.0-fold (0.00 log units), on the low side; low and high end bracket the measured number.
By their numbers in this assay, from the lowest: compounds 3, 4, 2 and 1 (each within the scatter of the next).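

In this assay the exchange of 3,4,5-trimethoxyphenyl for 3,4,5-trifluorophenyl on the amine nitrogen gives a 1.1-fold higher number from compound 3 to compound 4 (0.04 log units; within the scatter) even though the entering group has fewer heavy atoms and no hydrogen-bond acceptors. The other two comparisons also stay within the scatter, with a 1.0-fold lower number from compound 2 to compound 4 (0.00 log units; within the scatter) and a 1.1-fold lower number from compound 1 to compound 4 (0.04 log units; within the scatter) on the same read-out. Across these four aryl groups, replacing the methoxy groups with fluorine atoms therefore leaves this read-out where it was, which extends the earlier exchanges to a group without oxygen. No measurement shown offers an explanation for this flat result. On these data alone, whether an alkyl chain or an aryl group carrying a carboxylic acid or an amine on this nitrogen would shift the read-out remains open. Changes elsewhere on the shared core also remain open.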